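This account rests on a few compounds, and the source may have more. Where it says the series, first, only, none or still open, it means among the compounds named here.

Working notes on the series in a functional assay on HEK293 cells for agonist activity at Toll-like receptor 8 (Homo sapiens), read by reporter gene assay; on this read-out lower numbers stand for an effect already at smaller amounts and higher numbers for an effect only at larger amounts of compound. Compound 2 `CCOC(=O)CNc1oc2c(C)ncc(CO)c2c1Nc1ccccn1` gives "not active" (no number reported) in this assay, and compound 1 `Cc1ncc(CO)c(-c2nc3ccccn3c2NC2CCCCC2)c1OCc1ccccc1` gives "not active" (no number reported) in this assay as well, so neither of these two has a number that would place it. Within the data shown here, the one measured number comes from compound 3 `Cc1ncc(CO)c2c(Nc3ccccn3)c(NC3CCCCC3)oc12`, which in this assay gives 6930 nM. Compound 4 `Cc1ncc(CO)c2c(Nc3ccccn3)c(NC(C)(C)C)oc12` is still to be measured in this assay. It differs from compound 2 in one place: tert-butyl in place of (ethoxycarbonyl)methyl on a nitrogen on an aromatic ring. Compound 2, with the ((ethoxycarbonyl)methyl)amino group, has no reported number, whereas compound 3 does have a measured number; compound 4, with its (tert-butyl)amino group, can only be placed against these two facts. A step from no measurable activity toward a measured number in this assay is expected, with a real chance that the assay again reports no number. Compound 4 is expected to give about 9000 nM, within a range of 2000 nM to 40000 nM.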

Compound 4, half-maximal effective concentration: "not active" (no number reported)
Compound 4 has no reported number here; the estimate stays without a comparison.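

Compound 2 and compound 4 both stand without a number in this assay and so no step can be read between them. The compounds shown leave open how far the (tert-butyl)amino and ((ethoxycarbonyl)methyl)amino groups differ on this read-out. Nothing available bears on this result.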